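Pyridine for Furan on a Shared Lactone Core

This account rests on a few compounds, and the source may have more. Where it says the series, first, only, none or still open, it means among the compounds named here.

Compound 1 `CCOC(=O)C12C(=O)OCC=C1COC2c1cccc(Cl)c1` gives in a functional assay on QGY cells (Homo sapiens) for cytotoxicity, read by MTT assay (a higher number here means a weaker inhibitor, a lower number a stronger inhibitor), only a limit, > 1000000 nM.
Compound 2 `CCOC(=O)C12C(=O)OCC=C1COC2c1ccc(Cl)cc1` gives in this assay only a limit, > 1000000 nM.
Compound 3 `CCOC(=O)C12C(=O)OCC=C1COC2c1ccco1` gives in this assay only a limit, > 1000000 nM.

Compound 3 therefore stands at the edge of what this assay can report, and the other two sit at the same edge (the limit of > 1000000 nM in this assay, at which 3 of the 3 values shown sit). Compound 4 `CCOC(=O)C12C(=O)OCC=C1COC2c1ccccn1` differs from compound 3 by pyridin-2-yl in place of furan-2-yl on a saturated ring carbon. The measured steps at this same position, a step that the two limits leave unreadable from compound 1 to compound 3 and a step that the two limits leave unreadable from compound 2 to compound 3, carry no readable size: each runs from one limit to another. With every value at the limit, no direction can be read from the data. Compound 4 is expected to stay near that limit, a step that the limit leaves unreadable from compound 3 to compound 4. Compound 4 is estimated at 1500000 nM, between 300000 nM and 10000000 nM.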

Compound 4, half-maximal inhibitory concentration: > 1000000 nM
Compound 4 gave a limit, no number (the forecaster's own chance of this, stated with the estimate: 85%); the middle value does not contradict the limit.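

Compound 4 adds no readable step against compound 1, compound 2 or compound 3, because each value is only a limit: the limit of > 1000000 nM in this assay, at which 4 of the 4 values shown sit.

These compounds leave open whether any group on this saturated ring carbon can give the shared core a measurable value in this assay.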